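The source may report more compounds than this note shows. Statements on the series, on what has been measured and on what is new or still open speak of the compounds shown alone.

In a functional assay on BGC-823 cells (Homo sapiens) for cytotoxicity, read by MTT assay (a higher number here means a weaker inhibitor, a lower number a stronger inhibitor), compound 3 `Cc1nc(Nc2ccccc2)sc1C(=O)/C=C/c1ccccc1` gives 19500 nM. Compound 2 `Cc1nc(Nc2ccc(Cl)c(Cl)c2)sc1C(=O)/C=C/c1ccc(Cl)cc1` gives 22700 nM in this assay, a number that lies within the usual scatter of the number for compound 3, so the two cannot be told apart. Compound 1 `Cc1cccc(Nc2nc(C)c(C(=O)/C=C/c3ccc(Cl)cc3)s2)c1` reaches only the limit of this assay, > 25000 nM. Going by the values given here, the one measured step, an at least 1.1-fold lower number from compound 1 to compound 2 (0.04 log units; that floor lies within the scatter), concerns the group on a nitrogen on an aromatic ring and stays within the scatter. Compound 4 `Cc1nc(Nc2ccccc2)sc1C(=O)/C=C/c1ccc(Cl)cc1` differs from compound 3 by chloro in place of hydrogen on an aromatic carbon. Among the compounds with values here, no measured step touches that ring, and the single known step is flat, so no shift beyond the scatter is expected. Compound 4 is therefore expected to give about 16000 nM in this assay, between 7000 nM and 32000 nM, an estimated step of a 1.2-fold lower number from compound 3 to compound 4 (0.09 log units; within the scatter).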

Compound 4, half-maximal inhibitory concentration: > 25000 nM
Compound 4: no number, only a limit; the forecaster's own chance of this, stated with the estimate: 20%; middle value at least 1.5-fold (0.19 log units) away from the limit.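

Chloro in place of hydrogen on this six-membered aromatic ring, para to a large group, gives an at least 1.2-fold higher number from compound 3 to compound 4 (0.10 log units; that floor lies within the scatter) in this assay, so the change brings no readable gain. Phenyl in place of 3,4-dichlorophenyl on the nitrogen gives an at least 1.1-fold higher number from compound 2 to compound 4 (0.04 log units; that floor lies within the scatter), while the remaining step, joining two limits, cannot be read. Both readable steps are only floors, and their true size stays hidden at the limit: the limit of > 25000 nM in this assay, at which 2 of the 4 values shown sit.

From the compounds shown here alone, whether a methoxy group, an amine or a carboxylic acid at this position would lower the number remains open.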